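Replacing ethyl with 4-fluorophenyl: expected cytotoxicity of compound 3

This account rests on a few compounds, and the source may have more. Where it says the series, first, only, none or still open, it means among the compounds named here.

Measured so far in an ADME assay on MT4 cells (Homo sapiens) for cytotoxicity; on this read-out higher numbers stand for lower toxicity in this test and lower numbers for higher toxicity in this test
- compound 1 `Fc1ccc(NC(=S)Nc2cccc(C(F)(F)F)c2)cc1Cl` gives 8000 nM
- compound 2 `CCNC(=S)Nc1cccc(C(F)(F)F)c1` gives > 100000 nM (a limit, not a number)

Compound 2 reads > 100000 nM in this assay, and this value is a limit of the assay, not a number. For the measured compounds named here, the only number so far comes from compound 1 (8000 nM), so the two values mark out a wide gap with one open end.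

The next compound is compound 3 `Fc1ccc(NC(=S)Nc2cccc(C(F)(F)F)c2)cc1`, which differs from compound 2 by one change (4-fluorophenyl in place of ethyl on an amide-type nitrogen), with 4-fluorophenyl in place of ethyl on an amide-type nitrogen. Going by the values given here, no step between measured compounds is available to size this change. The expectation rests on compound 1 (8000 nM), which, like compound 3, carries a six-membered aromatic ring at that place and not an ethyl group. A large move beyond the scatter is therefore expected in this assay, towards lower numbers and so higher toxicity in this test, as the estimated at least 6.6-fold lower number from compound 2 to compound 3 (0.82 log units; beyond the scatter) shows. Compound 3 is estimated at 15000 nM, with an expected range of 5000 nM to 50000 nM.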

Compound 3, half-maximal cytotoxic concentration: 31000 nM
For compound 3 the middle estimate is 2.1-fold (0.32 log units) below the measured one; low and high end bracket the measured number.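

In this assay, for the compounds shown here, 4-fluorophenyl in place of ethyl on the amide-type nitrogen gives an at least 3.2-fold lower number from compound 2 to compound 3 (0.50 log units; beyond the scatter), so the first step at this place ties the aromatic ring to lower numbers and higher toxicity in this test. Compound 2 reads as a limit of the assay and not a number, so this step sets only a minimum size: the limit of > 100000 nM in this assay, at which 1 of the 3 values shown sits.

The ring's substitution also counts, since hydrogen in place of chloro on an aromatic carbon gives a 3.9-fold higher number from compound 1 to compound 3 (0.59 log units; beyond the scatter), which shows that the 4-fluorophenyl ring alone does not fix the read-out and that the aromatic ring's other substituents can shift it beyond the scatter.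

The compounds shown leave open whether a longer chain such as n-butyl, or an unsubstituted phenyl, on the amide-type nitrogen would sit nearer the ethyl or the 4-fluorophenyl end of this range. Also open, going by these compounds, is whether the chloro step holds for other groups on that aromatic carbon, such as a methoxy group, an amine or a carboxylic acid, since a single pair of compounds sizes that change.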